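From benzyloxy to hydroxy at the assay limit

The source may hold more compounds than are shown below. What is called first, only, known or untested is meant among the compounds shown, and "the series" means these compounds.

In a functional assay on HepG2 cells (Homo sapiens) for antiproliferative activity, read by MTT assay, with a stated time of 72 h (on this read-out higher numbers stand for weaker inhibition and lower numbers for stronger inhibition), compound 1 `Cc1c(CC(O)COCc2ccccc2)[nH]c(=O)[nH]c1=O` gives > 100000 nM, which is a limit. Compound 2 `C[Si](C)(C)CCOCn1c(CC(O)COCc2ccccc2)cc(=O)[nH]c1=O` gives > 100000 nM, also a limit. Compound 3 `Cc1c(CC(O)COCc2ccccc2)n(COCC[Si](C)(C)C)c(=O)[nH]c1=O` gives > 100000 nM, again a limit and not a number. The series thus shows (the limit of > 100000 nM in this assay, at which 3 of the 3 values shown sit).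

Compound 4 `Cc1c(CC(O)CO)n(COCC[Si](C)(C)C)c(=O)[nH]c1=O` carries hydrogen in place of benzyl on an oxygen on a saturated carbon, changing benzyloxy to hydroxy: hydrogen in place of benzyl on an oxygen on a saturated carbon. The measured steps are a step that the two limits leave unreadable from compound 1 to compound 3 and a step that the two limits leave unreadable from compound 2 to compound 3. Neither touches the benzyl group, and neither gives a size to carry over, so no clear direction is expected in this assay. The estimate is a step that the limit leaves unreadable from compound 3 to compound 4. Compound 4 is expected near 120000 nM, within an estimated range of 40000 nM to 300000 nM.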

Compound 4, half-maximal inhibitory concentration: > 100000 nM
Compound 4: no number, only a limit (the forecaster's own chance of this, stated with the estimate: 85%); the middle value does not contradict the limit.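

Compound 3 and compound 4 both stand only as limits in this assay, so the step between them cannot be read. The compounds shown leave open what actual number any of them would give.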